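Working notes: N-aryl variation on the shared core

A few compounds are considered here, and "the series" means these few. Any claim that something is new, unique, unknown or untested is made for them only; others in the source may bear on it.

Measured so far:
- compound 1 `O=C(Nc1ccc(Oc2ccnc3[nH]ccc23)cc1)c1cn(-c2ccc(F)cc2)c2ccccc2c1=O`: 720 nM
- compound 2 `O=C(Nc1ccc(Oc2ccnc3[nH]ccc23)cc1)c1cn(-c2ccc(C(F)(F)F)cc2Cl)c2ccccc2c1=O`: 3570 nM
- compound 3 `Cn1ccc2c(Oc3ccc(NC(=O)c4cn(-c5ccc(F)cc5)c5ccccc5c4=O)cc3F)ccnc21`: "not determined" (no result reported)

In a functional assay on MCF7 cells (Homo sapiens) for inhibition, read by MTT assay, with a stated time of 72 h (a higher number here means a weaker inhibitor, a lower number a stronger inhibitor), compound 1 gives 720 nM and compound 2 gives 3570 nM. Compound 3 stands at "not determined" (no result reported) and so cannot be placed against compounds 1 and 2. Compound 4 `Cn1ccc2c(Oc3ccc(NC(=O)c4cn(-c5ccc(Br)cc5F)c5ccccc5c4=O)cc3F)ccnc21` differs from compound 3 in that (4-bromo-2-fluorophenyl in place of 4-fluorophenyl on an aromatic nitrogen). Going by the values given here, the only measured step bears on it: a 5.0-fold higher number from compound 1 to compound 2 (0.70 log units; beyond the scatter), where a halogen-bearing phenyl carrying a larger group likewise replaced 4-fluorophenyl on the aromatic nitrogen. On that basis a weakening of modest size in this assay is expected for compound 4, with no direct anchor for compound 3 itself. Compound 4 is therefore estimated at 2000 nM, with a likely range of 500 nM to 8000 nM.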

Compound 4, half-maximal inhibitory concentration: 420 nM
Beside the measured number, compound 4's estimate is 4.8-fold (0.68 log units) above it; the whole stated range lies above it.
By their numbers in this assay, from the lowest: compounds 4 and 1 (each within the scatter of the next); then compound 2.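

Going by these compounds alone, compound 3 has no single number, so no step from compound 3 to compound 4 can be read. The compounds shown leave open how 4-bromo-2-fluorophenyl compares with 4-fluorophenyl on the core of compound 4. No evidence on the cause of compound 4's result is available.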